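Chalcones on a shared core: a thiophene swapped for a chlorophenol

The compounds below may be only part of what the source reports. "The series", "measured", "known", "first", "only" and "open" are said of these compounds alone.

Three chalcones sharing one core have been examined in a functional assay on SK-OV-3 cells (Homo sapiens) for antiproliferative activity, read by MTT assay, with a stated time of 24 h; on this read-out higher numbers stand for weaker inhibition and lower numbers for stronger inhibition. Compound 1 `COc1cc(OC)c(OC)cc1/C=C/C(=O)c1ccc(OC)c2c1OC(C)(C)C=C2` was found at the detection limit, > 10000 nM. Compound 3 `CCOc1cc(/C=C/C(=O)c2ccc(OC)c3c2OC(C)(C)C=C3)ccc1O` likewise sits at a limit of the assay, > 10000 nM. Compound 2 `COc1ccc(C(=O)/C=C/c2ccsc2)c2c1C=CC(C)(C)O2` also gives only a limit, > 10000 nM. Thus every value shown so far is a limit rather than a number, and compound 2 stands nowhere apart from the other two; no ordering among the three can be read from these figures. The only thing that the measured values show is described by the limit of > 10000 nM in this assay, at which 3 of the 3 values shown sit.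

Compound 4 `COc1ccc(C(=O)/C=C/c2cc(Cl)ccc2O)c2c1C=CC(C)(C)O2` has not yet been measured in this assay . It differs from compound 2 in one place: 5-chloro-2-hydroxyphenyl in place of thiophen-3-yl on a double-bonded chain carbon bound to a double-bonded chain carbon. Among the compounds with values here, no step between measured compounds is available that would tell how such a change acts on this core, so any expectation rests on the three limits alone. He expects the step from compound 2 to compound 4, a step that the limit leaves unreadable from compound 2 to compound 4, to be small or none beyond the scatter, in either direction. Compound 4 is therefore estimated at 15000 nM, with a range from 4000 nM to 60000 nM, and most probably again only a limit.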

Compound 4, half-maximal inhibitory concentration: 6270 nM
Compound 4: the middle estimate sits 2.4-fold (0.38 log units) above what was measured, within the range that was stated.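

In this assay compound 4 is the only one of the four compounds shown that gives a number rather than a limit, 6270 nM, so this place on the shared core is the one spot where a change has brought a reading inside the measurable range. With 5-chloro-2-hydroxyphenyl in place of thiophen-3-yl on a double-bonded chain carbon bound to a double-bonded chain carbon, the result is an at least 1.5-fold lower number from compound 2 to compound 4 (0.20 log units; that floor lies within the scatter); the true step may be larger, but the printed floor alone does not set it beyond the usual scatter. The direction is therefore suggested rather than established, and its size cannot be read, since only a floor is available: the limit of > 10000 nM in this assay, at which 3 of the 4 values shown sit.

The compounds shown do not separate the six-membered ring, the chlorine and the hydroxy group from one another, so it stays open which of these carries the step. They also leave open what an amine, a carboxylic acid or a methoxy group on that ring would give in this assay.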